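Swapping the acyl ring on a shared amide core

This account rests on a few compounds, and the source may have more. Where it says the series, first, only, none or still open, it means among the compounds named here.

Compound 1, `COc1ccc(N(C)C(=O)N(C)c2cc(OC)c(OC)c(OC)c2)cc1`: >= 125000 nM
Compound 2, `COc1cc(N(C)C(=O)c2cccc(F)c2)cc(OC)c1OC`: >= 125000 nM
Compound 3, `COc1cc(N(C)C(=O)c2cccc([N+](=O)[O-])c2)cc(OC)c1OC`: >= 125000 nM

Of the compounds shown here, three have been tested in a functional assay on ONS-76 cells (Homo sapiens) for cytotoxicity, read by MTT assay, with a stated time of 72 h; a lower number here means a stronger inhibitor, a higher number a weaker inhibitor. For compound 1 the result >= 125000 nM is a limit of the assay, not a number. For compound 2 the result >= 125000 nM is likewise a limit. For compound 3 the result >= 125000 nM is a limit as well. The picture is summed up by the limit of >= 125000 nM in this assay, at which 3 of the 3 values shown sit. Because of the limit of >= 125000 nM in this assay, at which 3 of the 3 values shown sit, the step that the two limits leave unreadable from compound 2 to compound 3 cannot be read, and compound 2 cannot be placed in any order against compound 1 or compound 3; it simply stands at the limit with the others.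

Compound 4, `COc1ccc(C(=O)N(C)c2cc(OC)c(OC)c(OC)c2)cc1`, differs from compound 2 by 4-methoxyphenyl in place of 3-fluorophenyl on a carbonyl carbon. Among the measured compounds shown here, no measured step speaks to this change, since the one step measured within the shared core is unreadable. With every measured value sitting at the limit, no step beyond the scatter can be expected in either direction. Compound 4 is therefore expected to give 125000 nM in this assay. That estimate means an expected step of a number no higher from compound 2 to compound 4 (the limit leaves the size open), most likely reported again only as a limit.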

Compound 4, half-maximal inhibitory concentration: >= 125000 nM
Compound 4 ended at the assay's limit; the forecaster's own chance of this, stated with the estimate: 80%; the middle value sits exactly at the limit.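

Compound 2 and compound 4 both sit at a limit rather than at a number, so swapping 3-fluorophenyl for 4-methoxyphenyl gives no readable step, because all the results stand at one limit: the limit of >= 125000 nM in this assay, at which 4 of the 4 values shown sit.

The compounds shown leave open which change to the shared core, if any, would give a value readable as a number.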